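A few compounds are considered here, and "the series" means these few. Any claim that something is new, unique, unknown or untested is made for them only; others in the source may bear on it.

Of the compounds shown here, three have been tested in a functional assay on cells (Panel prostate (Carcinoma cell lines), Homo sapiens) for inhibition; a higher number here means a weaker inhibitor of growth, a lower number a stronger inhibitor of growth. Compound 1, `Cc1ccc(/C=C2\CN(C)CC3C2=NN(c2ccccc2)C3c2ccc(C)cc2)cc1`, gives 69500 nM in this assay. Compound 2, `COc1ccc(/C=C2\CN(C)CC3=C2N=C(S)NC3c2ccc(OC)cc2)cc1`, is built on a different core and gives 9100 nM. Compound 3, `CN1C/C(=C\c2cccs2)C2=NN(C)C(c3cccs3)C2C1`, gives 59500 nM. Among these three numbers compound 3 stands second highest; its value and that of compound 1 lie within the usual scatter of each other, so no order between them can be claimed, whereas the value of compound 2 is clearly lower than that of compound 3, a gap that goes beyond the scatter.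

Compound 4, `CN1C/C(=C\c2cccs2)C2=NN(c3ccccc3)C(c3cccs3)C2C1`, has not yet been measured in this assay. It differs from compound 3 in one place: phenyl in place of methyl on an amine nitrogen in a ring. The phenyl group sits on the amine nitrogen of the five-membered non-aromatic ring with two nitrogens, with the thiophen-2-yl groups left unchanged.

Among the compounds with values here, no measured pair shows this methyl-to-phenyl exchange on its own, so the expected step from compound 3 to compound 4 rests on compound 1, which carries a phenyl on the same ring nitrogen and gives 69500 nM, close to compound 3. The step of a 1.1-fold higher number from compound 3 to compound 4 (0.04 log units; within the scatter) is therefore expected to be small and within the scatter. Compound 4 is expected to give about 65000 nM in this assay, with a plausible range from 25000 nM to 170000 nM.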

Compound 4, concentration for 50% growth inhibition: 19300 nM
Beside the measured number, compound 4's estimate is 3.4-fold (0.53 log units) above it, and the stated range ends above it.
By their numbers in this assay, from the lowest: compound 2; then compound 4; then compounds 3 and 1 (each within the scatter of the next).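

In this assay the exchange of methyl for phenyl on the amine nitrogen in the five-membered non-aromatic ring with two nitrogens gives a 3.1-fold lower number from compound 3 to compound 4 (0.49 log units; beyond the scatter) and this modest step lies beyond the scatter. Within the data shown here, this is the only measured pair here that differs in one place, so it alone shows that the group on this ring nitrogen, next to the ring atom that bears a thiophen-2-yl group, can shift growth inhibition on this core, with the phenyl compound 4 the stronger inhibitor of the pair. Nothing at hand explains the direction or size of this step, so it stands as an observation only.

A single pair leaves open how far this trend extends, and whether a benzyl group, an ethyl chain or a phenyl ring carrying chlorine on the same nitrogen would continue it or reverse it. It also leaves open whether the same exchange would give a similar step if the thiophen-2-yl groups were replaced by a pyridine ring.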